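The source may report more compounds than this note shows. Statements on the series, on what has been measured and on what is new or still open speak of the compounds shown alone.

Compound 2, with the structure `CC(C)(C)n1ncc(OCc2nnc(-c3ccc(Cl)cc3)s2)c(Cl)c1=O`, gives 106 ug/mL in a functional assay on the whole organism for inhibition, with Mythimna separata as the target, with a stated time of 5 days (a lower number here means that less compound is needed, a higher number that more compound is needed for the effect), the highest of the three numbers recorded. Compound 1, `CC(C)(C)n1ncc(OCc2nnc(-c3ccccc3Cl)o2)c(Cl)c1=O`, gives 61.2 ug/mL in this assay, a value that lies within the scatter of compound 2. Compound 3, `CC(C)(C)n1ncc(OCc2nnc(-c3cccc(F)c3)o2)c(Cl)c1=O`, gives 7.1 ug/mL, and here the gap to compound 2 is beyond the scatter. Compound 4, `CC(C)(C)n1ncc(OCc2nnc(-c3ccc(F)cc3)s2)c(Cl)c1=O`, is not yet measured. It differs from compound 2 by fluoro in place of chloro on an aromatic carbon. Among the compounds with values here, the only measured step that bears on this change is an 8.6-fold lower number from compound 1 to compound 3 (0.94 log units; beyond the scatter), where chlorine gave way to fluorine while the point of attachment on the phenyl ring also moved, so it is not a clean guide. Given that step, a lower number is expected for compound 4, but a smaller one than seen between compound 1 and compound 3, with the step from compound 2 to compound 4 estimated at a 2.7-fold lower number from compound 2 to compound 4 (0.42 log units; beyond the scatter). Compound 4 is therefore expected to give about 40 ug/mL in this assay, within a range from 12 ug/mL to 130 ug/mL.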

Compound 4, half-maximal effective concentration: 21.5 ug/mL
Compound 4: middle estimate off by 1.9-fold (0.27 log units), on the high side; measured number inside the range.
By their numbers in this assay, from the lowest: compound 3; then compound 4; then compounds 1 and 2 (each within the scatter of the next).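

Within the data shown here, compound 2 and compound 4 give the first clean reading of the halogen alone. With the place on the ring held fixed, para to a large group, the change from 4-chlorophenyl to 4-fluorophenyl gives in this assay a 4.9-fold lower number from compound 2 to compound 4 (0.69 log units; beyond the scatter), so the halogen by itself is enough to move the number beyond the scatter, without any shift in its point of attachment. No measurement shown here offers an explanation for this effect of the change.

From the compounds shown here alone, this is a single pair in one core, so it remains open whether the same exchange would act alike on the core of compound 3. Also open, going by these compounds, is how a hydrogen, a methoxy group or a trifluoromethyl group in this place would compare with fluoro.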